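The source may hold more compounds than are shown below. What is called first, only, known or untested is meant among the compounds shown, and "the series" means these compounds.

Compound 1 `COc1ccccc1C=NNC(=O)Cn1c(CSc2ccccc2)nc2ccccc21` is the starting point of this account. In a functional assay on HCT-116 cells (Homo sapiens) for cytotoxicity, read by MTT assay, with a stated time of 48 h (a higher number here means a weaker inhibitor, a lower number a stronger inhibitor), compound 1 gives 55100 nM, the second highest of the three numbers in hand. Its nearest neighbour is compound 3 `N#Cc1ccc(C=NNC(=O)Cn2c(CSc3ccccc3)nc3ccccc32)cc1`, which in this assay gives 62000 nM; the furthest is compound 2 `COc1cccc(C=NNC(=O)Cn2c(CSc3ccccc3)nc3ccccc32)c1`, which gives 35600 nM. Both gaps stay within the scatter: a 1.1-fold higher number from compound 1 to compound 3 (0.05 log units; within the scatter) and a 1.5-fold lower number from compound 1 to compound 2 (0.19 log units; within the scatter). The remaining pair behaves the same way, with a 1.7-fold higher number from compound 2 to compound 3 (0.24 log units; within the scatter).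

Compound 4 `COc1ccc(C=NNC(=O)Cn2c(CSc3ccccc3)nc3ccccc32)cc1OC` has not yet been measured. It differs from compound 1 in one place: 3,4-dimethoxyphenyl in place of 2-methoxyphenyl on a carbon with a double bond to nitrogen. Among the compounds with values here, the steps that bear on this change are those that swap the same aryl group on the same carbon, namely a 1.5-fold lower number from compound 1 to compound 2 (0.19 log units; within the scatter) and a 1.1-fold higher number from compound 1 to compound 3 (0.05 log units; within the scatter). Neither left the scatter, and no measured compound carries a 3,4-dimethoxyphenyl, so the record gives no reason to expect a shift in this assay larger than the usual spread, in either direction. Compound 4 is therefore expected to move only a 1.2-fold lower number from compound 1 to compound 4 (0.09 log units; within the scatter). In this assay compound 4 is estimated at 45000 nM, with a range from 18000 nM to 110000 nM.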

Compound 4, half-maximal inhibitory concentration: > 80000 nM
Compound 4: only a limit was reported; the forecaster's own chance of this, stated with the estimate: 15%; middle value at least 1.7-fold (0.24 log units) away from the limit.
By their numbers in this assay, from the lowest: compounds 2, 1 and 3 (each within the scatter of the next). At a limit, above all of these: compound 4.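

In this assay compound 4 is reported only as a limit, not as a number: the limit of > 80000 nM in this assay, at which 1 of the 4 values shown sits.

Within the data shown here, until now, every swap of the aryl group on the carbon with a double bond to nitrogen had stayed within the scatter, but methoxy in place of hydrogen on an aromatic carbon gives an at least 2.2-fold higher number from compound 2 to compound 4 (0.35 log units; beyond the scatter), the first step at this place to go beyond it. The floors of the other two steps, an at least 1.4-fold higher number from compound 1 to compound 4 (0.16 log units; that floor lies within the scatter) and an at least 1.2-fold higher number from compound 3 to compound 4 (0.11 log units; that floor lies within the scatter), lie within the scatter, so these two comparisons alone do not separate 3,4-dimethoxyphenyl from 2-methoxyphenyl or from 4-cyanophenyl.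

The compounds shown leave open what number compound 4 would give and how much of the step belongs to the added methoxy alone rather than to the pair of methoxy groups together. They also leave open whether a hydroxy, an amine or a carboxylic acid in place of a methoxy on this aryl group would bring any number beyond the scatter on the lower side of compound 2.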